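Swapping the aryl group for a methylfuran on the shared core

The source may hold more compounds than are shown below. What is called first, only, known or untested is meant among the compounds shown, and "the series" means these compounds.

Measured compounds:
- Compound 1, `Cc1ccc(C2C(C#N)=C(N)N(c3ccc(S(N)(=O)=O)cc3)C3=C2C(=O)CCC3)cc1`: 50%
- Compound 2, `N#CC1=C(N)N(c2ccc(S(N)(=O)=O)cc2)C2=C(C(=O)CCC2)C1c1ccc(O)cc1`: 100%
- Compound 3, `N#CC1=C(N)N(c2ccc(S(N)(=O)=O)cc2)C2=C(C(=O)CCC2)C1c1cccc([N+](=O)[O-])c1`: 73%

All three share one core and differ only in the group attached to a saturated ring carbon of that core. In a functional assay on Ehrlich cells (Mus musculus) for antiproliferative activity, read by trypan blue exclusion, with a stated time of 2 h, tested at 50 ug/mL (on this read-out lower numbers stand for a weaker effect and higher numbers for a stronger effect at the one concentration tested), compound 3 stands second of the three: the step of a number 23 percentage points higher from compound 1 to compound 3 (beyond the scatter) lifts it above compound 1, while the step of a number 27 percentage points lower from compound 2 to compound 3 (beyond the scatter) leaves it clearly under compound 2, which gave the highest number seen here.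

Compound 4, `Cc1ccoc1C1C(C#N)=C(N)N(c2ccc(S(N)(=O)=O)cc2)C2=C1C(=O)CCC2`, has not yet been measured. It differs from compound 3 in one place: 3-methylfuran-2-yl in place of 3-nitrophenyl on a saturated ring carbon.

Within the data shown here, two measured steps bear on this change, since both exchange the group on the same saturated ring carbon: a number 23 percentage points higher from compound 1 to compound 3 (beyond the scatter) and a number 27 percentage points lower from compound 2 to compound 3 (beyond the scatter). Both were modest, one upward and one downward, so exchanging this group has so far moved the read-out by a moderate amount in either direction. Among the measured compounds shown here, no measured compound carries a furan, so there is no direct guide to which way compound 4 will go. On that basis a modest step is expected, more likely downward than upward, giving a number 13 percentage points lower from compound 3 to compound 4 (beyond the scatter) as the expected change. Compound 4 is therefore estimated at 60%, within a range from 30% to 90%.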

Compound 4, a percentage reported as activity, at one concentration (the size of the read-out at that concentration, not a potency): 40%
Beside the measured number, compound 4's estimate is 20 percentage points above it; the measured number falls inside the stated range.
By their numbers in this assay, from the lowest: compounds 4 and 1 (each within the scatter of the next); then compound 3; then compound 2.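

In this assay, the 3-methylfuran-2-yl group shows that a change at this saturated ring carbon can take the read-out down by a large amount: there is a number 33 percentage points lower from compound 3 to compound 4 (beyond the scatter) and also a number 60 percentage points lower from compound 2 to compound 4 (beyond the scatter) in the comparison with the 4-hydroxyphenyl group. Against the 4-methylphenyl group the picture differs, with a number 10 percentage points lower from compound 1 to compound 4 (within the scatter) so that a five-membered aromatic ring with one hetero atom cannot be told apart here from that six-membered ring of carbon only, and having a six-membered aromatic ring of carbon only is not enough for a high number, as compound 1 shows. Nothing available explains why these groups rank as they do.

As far as these compounds go, all four groups at this carbon are aromatic rings, so it remains open how a saturated group such as cyclohexyl or a longer chain such as n-butyl would read, and whether the furan's methyl matters, which the plain furan-2-yl group would test. From the compounds shown here alone, it also remains open whether the high number of compound 2 at 100% is tied to the hydroxy group or would persist with an amine or a carboxylic acid in its place on the phenyl ring.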